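The source may hold more compounds than are shown below. What is called first, only, known or untested is meant among the compounds shown, and "the series" means these compounds.

Measured compounds:
- compound 1 `CCCc1n[nH]c2c(=O)n(NC(=O)c3ccncc3)c(-c3cccc(OC)c3)nc12`, in a functional assay on SK-OV-3 cells (Homo sapiens) for cytotoxicity, read by sulforhodamine B assay, with a stated time of 2 days, tested at 100 uM (on this read-out lower numbers stand for less inhibition and higher numbers for more inhibition at the one concentration tested (going by the name of the read-out)), compound 1 gives 4.04%
- compound 2 `O=C(Nn1c(-c2cccc([N+](=O)[O-])c2)nc2c(-c3ccco3)n[nH]c2c1=O)c1cccnc1`, in this assay compound 2 gives -0.61%
- compound 3 `CCCc1n[nH]c2c(=O)n(NC(=O)c3ccccc3)c(-c3cccc([N+](=O)[O-])c3)nc12`, in this assay compound 3 gives 28.8%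

Compound 3 stands at the highest number of the three, beyond the scatter from both compound 1 and compound 2; compound 1 and compound 2 lie within the scatter of each other, so nothing separates them. Compound 4 `CCCc1n[nH]c2c(=O)n(NC(=O)c3ccccc3)c(-c3cccc(OC)c3)nc12` has not yet been tested in this assay. Compound 4 is reached from compound 3 by one change: methoxy in place of nitro on an aromatic carbon, that is, 3-nitrophenyl to 3-methoxyphenyl. For the measured compounds named here, no measured pair shows this change alone. Compound 1, which also carries 3-methoxyphenyl but differs from compound 3 in a second place as well, sits far lower. In this assay compound 1 gives 4.04%, the only hint on hand. The step from compound 3 to compound 4 is therefore expected to go down, a number 18.8 percentage points lower from compound 3 to compound 4 (beyond the scatter), and probably beyond the scatter. Compound 4 is estimated at 10%, within a range from -5% to 25%.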

Compound 4, a percentage reported as inhibition, at one concentration (the size of the read-out at that concentration, not a potency): 9.96%
The estimate for compound 4 lay 0 percentage points above the measured number; measured number inside the range.
By their numbers in this assay, from the lowest: compounds 2, 1 and 4 (each within the scatter of the next, the first and the last beyond it); then compound 3.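

In this assay, the swap of 3-nitrophenyl to 3-methoxyphenyl can now be read alone, with the rest of the molecule held fixed, and it gives a number 18.8 percentage points lower from compound 3 to compound 4 (beyond the scatter). The group on this aromatic carbon therefore matters by itself, whereas the other place, with phenyl in place of pyridin-4-yl on the carbonyl carbon, gives a number 5.9 percentage points higher from compound 1 to compound 4 (within the scatter), so that swap separates nothing while 3-methoxyphenyl is present. Nothing on hand explains the step from nitro to methoxy.

On these data alone, this reading rests on a single pair, so it remains open whether the same step appears with pyridin-4-yl on the carbonyl carbon. As far as these compounds go, it is also open whether an amine or a nitrile on that aromatic carbon would give a number nearer to compound 3 or to compound 4.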